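From compound 2 to compound 4: swapping one aromatic group

This account rests on a few compounds, and the source may have more. Where it says the series, first, only, none or still open, it means among the compounds named here.

Of the compounds shown here, three have been measured so far in a functional assay on MDA-MB-436 cells (Homo sapiens) for antiproliferative activity, read by MTT assay, with a stated time of 48 h; a higher number here means a weaker inhibitor, a lower number a stronger inhibitor. Compound 1 `C=CS(=O)(=O)N1CCN(c2ncnc3ccc(-c4ccccc4)cc23)CC1` gives 23400 nM, compound 2 `C=CS(=O)(=O)N1CCN(c2ncnc3sc(-c4ccc(C(F)(F)F)cc4)cc23)CC1` gives 7080 nM and compound 3 `C=CS(=O)(=O)N1CCN(c2ncnc3sc(-c4cn(S(=O)(=O)c5ccccc5)c5ccccc45)cc23)CC1` gives 38000 nM. Compound 2 has the lowest number of the three, and its gaps to the other two are larger than the usual scatter of repeated measurements. No two of these compounds differ in only one place, so the data contain no direct measure of what a single change does.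

Compound 4 `C=CS(=O)(=O)N1CCN(c2ncnc3sc(-c4ccc(OC)nc4)cc23)CC1` has not yet been measured. It keeps the shared core of compound 2 and changes one group: 6-methoxypyridin-3-yl in place of 4-(trifluoromethyl)phenyl on an aromatic carbon. Here 6-methoxypyridin-3-yl takes the place of 4-(trifluoromethyl)phenyl on an aromatic carbon of a five-membered aromatic ring with 1 sulfur, next to the ring sulfur.

Compound 2 sits at the low end with 7080 nM, while compound 3, which carries a different group at this place, gives 38000 nM. A new group here is therefore expected to raise the number rather than lower it. The expected change is a moderate one, a 2.3-fold higher number from compound 2 to compound 4 (0.35 log units; beyond the scatter), towards a weaker inhibitor. For compound 4 the estimated value in this assay is 16000 nM, with an expected range from 5000 nM to 45000 nM.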

Compound 4, half-maximal inhibitory concentration: 11900 nM
The estimate for compound 4 lay 1.3-fold (0.13 log units) above the measured number; low and high end bracket the measured number.
By their numbers in this assay, from the lowest: compounds 2, 4, 1 and 3 (each within the scatter of the next, the first and the last beyond it).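

In this assay, putting 6-methoxypyridin-3-yl in place of 4-(trifluoromethyl)phenyl gives a 1.7-fold higher number from compound 2 to compound 4 (0.23 log units; within the scatter), the first direct measure of a single change in this set, and a step of this size cannot be told apart from repeat-to-repeat variation. At this place, on an aromatic carbon of a five-membered aromatic ring with 1 sulfur, next to the ring sulfur, a six-membered aromatic ring of carbon only can thus be exchanged for one with 1 hetero atom, and 0 hydrogen-bond acceptors in the group for 2, without a clear shift in the read-out. Nothing measured here explains this outcome or shows which part of either group matters, if any does.

For the compounds shown here, only two groups have been compared directly at this place, so a single pair cannot show how far this tolerance extends. Still open, from the compounds shown here alone, is whether an unsubstituted phenyl, a small amine such as morpholine, or a carboxylic acid at the same carbon would move the number beyond the usual scatter in this assay.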